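This account rests on a few compounds, and the source may have more. Where it says the series, first, only, none or still open, it means among the compounds named here.

Compound 1, `Cc1ccc(S(=O)(=O)NCc2ccc(CNC(=O)c3cccc(Cl)c3)cc2)cc1`: 100 nM
Compound 2, `O=C(NCc1ccc(CNS(=O)(=O)c2ccccc2)cc1)c1ccccc1F`: 1000 nM

In an assay on MDA-MB-231 cells for binding affinity to C-X-C chemokine receptor type 4 (Homo sapiens), read by immunofluorescence and microscopy, with stated times of 10 min and 30 min (a lower number here means that less compound is needed, a higher number that more compound is needed for the effect), compound 1 gives 100 nM, while compound 2 gives 1000 nM. For the measured compounds named here, compound 2 thus stands highest of the two numbers, and its only neighbour, compound 1, sits well below it, by a gap beyond the usual scatter. The next compound, compound 3, is `Cc1ccc(S(=O)(=O)NCc2ccc(CNC(=O)c3ccccc3F)cc2)cc1`. It differs from compound 2 in one place: methyl in place of hydrogen on an aromatic carbon. Going by the values given here, no pair of measured compounds isolates this change, so the expectation rests on the gap alone. Compound 3 is expected to give a moderately lower number, an estimated step of a 2.0-fold lower number from compound 2 to compound 3 (0.30 log units; within the scatter) that stays near the scatter. Compound 3 is estimated at 500 nM, between 150 nM and 1500 nM.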

Compound 3, effective concentration (reported as EC, without a stated level of effect): 1000 nM
The estimate for compound 3 lay 2.0-fold (0.30 log units) below the measured number; the range from low to high includes it.
By their numbers in this assay, from the lowest: compound 1; then compounds 2 and 3 (each within the scatter of the next).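

In this assay, methyl in place of hydrogen on the aromatic carbon para to a large group gives no change at the digits printed from compound 2 to compound 3 (within the scatter), so phenyl and 4-methylphenyl read alike here. With 4-methylphenyl kept, 2-fluorophenyl in place of 3-chlorophenyl on the carbonyl carbon gives a 10-fold higher number from compound 1 to compound 3 (1.00 log units; beyond the scatter), so this single change does shift the number beyond the scatter. No measurement is available to explain either result. Going by these compounds, whether an amine or a carboxylic acid on that same aromatic carbon would also leave the number unchanged remains open. So does whether the halogen itself or its place on the ring accounts for the step at the carbonyl end.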